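Compound 3 and the Open Question of Its Half-Life

A few compounds are considered here, and "the series" means these few. Any claim that something is new, unique, unknown or untested is made for them only; others in the source may bear on it.

In an ADME assay on a cell-free system (plasma, Mus musculus, strain CD-1) for metabolic stability, read by LC-MS, tested at 1 uM (on this read-out higher numbers stand for a longer-lived compound and lower numbers for a shorter-lived compound), compound 1 (`COc1ccccc1NC(=O)c1ccc(NC(=O)CCc2nc3ccccc3c(=O)[nH]2)cc1C`) gives 0.717 h while compound 2 (`O=C(CCc1nc2ccccc2c(=O)[nH]1)Nc1ccc(-c2nnc(-c3ccccc3)o2)cc1`) gives 2.03 h on the same read-out. Compound 2 therefore holds the higher of the two numbers, and its gap to compound 1 lies beyond the scatter. Compound 3 (`Cn1c(-c2ccc(NC(=O)CCc3nc4ccccc4c(=O)[nH]3)cc2)nc2ccccc21`) keeps the rest of compound 2 but carries 1-methyl-1H-benzimidazol-2-yl in place of 5-phenyl-1,3,4-oxadiazol-2-yl on an aromatic carbon. Within the data shown here, no measured pair that differs in one place shows what such an exchange does, since compounds 1 and 2 differ in more than one. The expectation in this assay is thus for no change beyond the scatter. The expected step is a 1.2-fold lower number from compound 2 to compound 3 (0.08 log units; within the scatter) and would stay within that scatter. Compound 3 is estimated at 1.7 h with an expected range from 0.7 h to 4 h as the likely span.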

Compound 3, half-life: > 8.33 h
Compound 3: only a limit was reported; the forecaster's own chance of this, stated with the estimate: 10%; middle value at least 4.9-fold (0.69 log units) away from the limit.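

Putting 1-methyl-1H-benzimidazol-2-yl in place of 5-phenyl-1,3,4-oxadiazol-2-yl gives an at least 4.1-fold higher number from compound 2 to compound 3 (0.61 log units; beyond the scatter) in this assay. This is the only comparison shown that differs in one place, and it shows that the group on this aromatic carbon, para to a large group, has a clear bearing on the half-life. For compound 3, > 8.33 h is a limit of the assay and not a number, so the full size of the step cannot be read: the limit of > 8.33 h in this assay, at which 1 of the 3 values shown sits.

The two groups differ together in heavy atoms, ring hetero atoms and hydrogen-bond acceptors, and the compounds shown do not separate these differences. On these data alone, whether a 1H-benzimidazol-2-yl without the methyl, or an amine or a carboxylic acid on the same carbon, would give a similar half-life remains open.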